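Hydroxy to methoxy: from compound 1 to compound 4

The source may report more compounds than this note shows. Statements on the series, on what has been measured and on what is new or still open speak of the compounds shown alone.

In a functional assay on HT-29 cells (Homo sapiens) for inhibition, read by MTT assay, with a stated time of 2 days (on this read-out lower numbers stand for stronger inhibition and higher numbers for weaker inhibition), compound 1 `Oc1ccc(/C=C/c2ccccc2O)cc1` gives 22 ug/mL while compound 3 `Nc1cccc(/C=C/c2ccccc2O)c1` gives 30.4 ug/mL and these two numbers sit within the scatter of each other, so neither can be ranked above the other. Compound 2 `Nc1ccccc1/C=C/c1ccc(O)cc1` reads > 100 ug/mL as a limit of the assay and not a number.

Compound 4 `COc1ccc(/C=C/c2ccccc2O)cc1` differs from compound 1 by a single change, hydroxy to methoxy (methyl in place of hydrogen on an oxygen on an aromatic ring), which means methyl in place of hydrogen on an oxygen on an aromatic ring. Going by the values given here, the only measured step (an at least 4.5-fold higher number from compound 1 to compound 2 (0.65 log units; beyond the scatter)) puts amino in place of hydroxy on an aromatic carbon and lies beyond the scatter, yet it alters a different hydroxy from the one changed in compound 4, so it is only a weak guide. No step beyond the scatter is therefore expected in this assay and any drift should be, if anything, towards a slightly higher number. The expected step (a 1.1-fold higher number from compound 1 to compound 4 (0.06 log units; within the scatter)) stays within the scatter. For compound 4 the estimated value is 25 ug/mL with an expected range from 10 ug/mL to 60 ug/mL in repeated measurements.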

Compound 4, half-maximal inhibitory concentration: 10 ug/mL
Beside the measured number, compound 4's estimate is 2.5-fold (0.40 log units) above it; the measured number falls inside the stated range.
By their numbers in this assay, from the lowest: compound 4; then compounds 1 and 3 (each within the scatter of the next). At a limit, above all of these: compound 2.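

In this assay, a methyl on the oxygen of this hydroxy gives a 2.2-fold lower number from compound 1 to compound 4 (0.34 log units; beyond the scatter), a modest step that lies beyond the usual scatter. The hydrogen on this oxygen is therefore not needed for inhibition in these cells, and replacing it is the first change shown that moves the number down. Compound 2, changed at the other hydroxy, reads > 100 ug/mL, which is a limit of the assay and not a number. Nothing at hand explains why the methyl lowers the number.

On these data alone, whether an ethyl group or a longer chain on this same oxygen would lower the number further stays open, as does the effect of a carboxylic acid in place of this hydroxy. The compounds shown also leave open whether a methyl on the oxygen of the other hydroxy would give a similar step.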